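A few compounds are considered here, and "the series" means these few. Any claim that something is new, unique, unknown or untested is made for them only; others in the source may bear on it.

Among the compounds with values here, in a functional assay on the whole organism for agonist activity, with Mus musculus as the target (a lower number here means that less compound is needed, a higher number that more compound is needed for the effect), compound 3 `CC(=O)N(C)CC#CCn1ccnc1` gives 1.4 mg/kg, the only actual number so far. Compound 1 `CC(=O)N(C)C(C)C#CCn1cncc1C` reports only a limit, > 100 mg/kg. Compound 2 `CC(=O)NCC#CCn1cncc1C` also reports only a limit, > 100 mg/kg. Both of these carry a ring methyl that compound 3 lacks, although they differ from it elsewhere too, so neither is a clean comparison. Compound 4 `CC(=O)N(C)CC#CCn1cncc1C` changes compound 3 in one place: methyl in place of hydrogen on an aromatic carbon. The expectation of a weaker result rests on compound 2, which shares this methyl and stops at the limit of > 100 mg/kg. The estimated step of an 18-fold higher number from compound 3 to compound 4 (1.25 log units; beyond the scatter) is large, towards a higher dose, and beyond the usual scatter. For compound 4 the expected value is 25 mg/kg, with an estimated range from 4 mg/kg to 100 mg/kg.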

Compound 4, dose for half-maximal effect: 45 mg/kg
The estimate for compound 4 lay 1.8-fold (0.26 log units) below the measured number; the measured number falls inside the stated range.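

The ring methyl now has a one-place comparison: in this assay, the change gives a 32-fold higher number from compound 3 to compound 4 (1.51 log units; beyond the scatter), so this methyl alone raises the dose needed. Within the data shown here, compound 4 still gives a real number, whereas the earlier compounds carrying this methyl stopped at a limit: the limit of > 100 mg/kg in this assay, at which 2 of the 4 values shown sit. Those limits give only bounds: methyl on the amide-type nitrogen gives an at least 2.2-fold lower number from compound 2 to compound 4 (0.34 log units; beyond the scatter), and hydrogen in place of the chain methyl gives an at least 2.2-fold lower number from compound 1 to compound 4 (0.34 log units; beyond the scatter).

On these data alone, whether ethyl or chlorine on this ring carbon would also raise the dose remains open. As far as these compounds go, the true size of both bounded steps also remains open.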